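Methoxy added to a benzimidazole series: tolerated concentration

This account rests on a few compounds, and the source may have more. Where it says the series, first, only, none or still open, it means among the compounds named here.

Measured compounds:
Compound 1 `COc1ccc(-c2nc3cc(/C(C)=N/O)ccc3[nH]2)c(OC)c1` gives > 100000 nM in an ADME assay on BHK-21 cells (Mesocricetus auratus) for cytotoxicity, read by MTT assay (a lower number here means that less compound is tolerated, a higher number that more compound is tolerated), which is a limit of the measurement rather than a number.
Compound 2 `COc1ccc(-c2nc3cc(/C(C)=N/O)ccc3[nH]2)c(OC)c1OC` gives > 100000 nM in this assay, again a limit and not a number.
Compound 3 `COc1ccc(-c2nc3cc(/C(C)=N/NC(N)=O)ccc3n2C2CCCCC2)cc1` gives "not determined" (no result reported) in this assay, so no result is reported for it.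

The change from compound 1 to compound 2 is methoxy in place of hydrogen on an aromatic carbon, and the step that the two limits leave unreadable from compound 1 to compound 2 cannot be read because of the limit of > 100000 nM in this assay, at which 2 of the 3 values shown sit. Compound 4 `COc1ccc(-c2nc3cc(/C(C)=N/NC(N)=O)ccc3n2C2CCCCC2)c(OC)c1` arises from compound 3 by methoxy in place of hydrogen on an aromatic carbon, the same kind of change, though here the place is ortho to a large group and meta to a methoxy group rather than ortho to two methoxy groups. The difference between the two cores is not broken down here. Since both measured compounds sit at the limit, compound 4 is expected to give about 100000 nM in this assay, estimated between 30000 nM and 300000 nM.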

Compound 4, half-maximal cytotoxic concentration: 19000 nM
The estimate for compound 4 lay 5.3-fold (0.72 log units) above the measured number; the whole stated range lies above it.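

In this assay, among these compounds, compound 3 gives "not determined" (no result reported), so no step to compound 4 can be read. On these data alone, what the added methoxy itself does to the tolerated concentration on this core stays open.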